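Replacing the amino group of compound 1: expected whole-organism effect

The source may report more compounds than this note shows. Statements on the series, on what has been measured and on what is new or still open speak of the compounds shown alone.

Compound 1 `Cc1nc2c(OCc3ccccc3)cccn2c1N` is the reference point of this short series. Among the compounds with values here, in a functional assay on the whole organism with Canis familiaris (Canis lupus familiaris) as the target, at a dose of 8 mg/kg by the oral route (a lower number here means a weaker effect, a higher number a stronger effect of the compound at the dose given), compound 1 gives 96%, the highest of the three numbers measured so far. Compound 2 `Nc1cnc2c(OCc3ccccc3)cccn12` gives 43%; the step of a number 53 percentage points lower from compound 1 to compound 2 (beyond the scatter) follows hydrogen in place of methyl on an aromatic carbon. Compound 3 `Cc1nc2c(OCc3cccs3)cccn2c1N` gives 86%; the step of a number 10 percentage points lower from compound 1 to compound 3 (within the scatter) follows thiophen-2-yl in place of phenyl on a saturated chain carbon bound to an oxygen on an aromatic ring. Compound 4 `Cc1nc2c(OCc3ccccc3)cccn2c1/N=C/N(C)C` is not yet measured. Its difference from compound 1: a group of 5 heavy atoms (3 carbon, 2 nitrogen; no ring) in place of one nitrogen atom, on an aromatic carbon. Within the data shown here, neither measured step touches the amino group, so no measured step bears directly on this change; the rest of compound 1 is kept. A step of a number 14 percentage points lower from compound 1 to compound 4 (beyond the scatter) is expected, within or just beyond the scatter, downward if anything. Compound 4 is estimated at 82%, with a range from 50% to 98%.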

Compound 4, a percentage reported as inhibition, in the whole organism at one dose (the size of the read-out at that dose, not a potency): 0%
Compound 4: middle estimate off by 82 percentage points, on the high side; the measured number lies below the stated range.
By their numbers in this assay, from the lowest: compound 4; then compound 2; then compounds 3 and 1 (each within the scatter of the next).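

Within the data shown here, the amino group position, untouched by the earlier steps, proves highly sensitive in this assay: the step of a number 96 percentage points lower from compound 1 to compound 4 (beyond the scatter) is the largest so far. The change removes the hydrogen-bond donor counted on the amino group and adds heavy atoms, and these two differences cannot be separated here. Nothing available explains the loss of effect.

On these data alone, whether a smaller group on the same aromatic carbon, such as methylamino or acetamido, would retain the effect remains open. So does whether a hydroxyl group there would.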